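The source may report more compounds than this note shows. Statements on the series, on what has been measured and on what is new or still open speak of the compounds shown alone.

Measured compounds:
compound 1 `CC(C)(C)CCc1cnc(CCc2ccc(-c3ccccc3C(=O)O)cc2)[nH]1` — 39 nM
compound 2 `CCCCc1cnc(Cc2ccc(-c3ccccc3C(=O)O)cc2)[nH]1` — > 10000 nM

Among the compounds with values here, in an in vitro functional assay on cells for agonist activity at Bombesin receptor subtype-3 (Homo sapiens), read by luminescence and calcium flux (on this read-out lower numbers stand for an effect already at smaller amounts and higher numbers for an effect only at larger amounts of compound), compound 1 gives 39 nM, the only number among the two values shown. Within the data shown here, compound 2 gives > 10000 nM, which is a limit of the assay and not a number; the two compounds differ in more than one place, so their two values show only that compound 1 is the one with a measured effect, as the evidence the limit of > 10000 nM in this assay, at which 1 of the 2 values shown sits, records. Among the measured compounds shown here, no step between two measured compounds that differ in one place is available, so any expectation for the next compound rests on the structural change alone.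

Compound 3 `Cc1ccccc1Cc1cnc(CCc2ccc(-c3ccccc3C(=O)O)cc2)[nH]1` is the step under consideration. It differs from compound 1 by 2-methylphenyl in place of neopentyl on a saturated chain carbon bound to an aromatic carbon. For the measured compounds named here, no measured step shows what such a change does on this core, so the estimate for compound 3 is held loose. The step from compound 1 to compound 3 is expected to be a modest loss, a 3.8-fold higher number from compound 1 to compound 3 (0.59 log units; beyond the scatter), beyond the usual scatter but not large. Compound 3 is therefore expected to give about 150 nM, with a range from 30 nM to 1500 nM.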

Compound 3, half-maximal effective concentration: 127 nM
For compound 3 the middle estimate is 1.2-fold (0.07 log units) above the measured one, and the stated range covers the measured number.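

In this assay, putting 2-methylphenyl in place of neopentyl on a saturated chain carbon bound to an aromatic carbon gives a 3.3-fold higher number from compound 1 to compound 3 (0.51 log units; beyond the scatter), so the loss is modest and compound 3 keeps a measured effect at 127 nM. Within the data shown here, this is the first step that can be read on the shared core, and it shows that this place can carry either a saturated branched end or a six-membered aromatic ring of carbon only and still give a measured number, with neopentyl ahead in this one comparison. Nothing measured here explains the size of this step.

A plain phenyl or a cyclohexyl at this place would separate the contribution of the ring from that of its methyl group, and the compounds shown cannot tell these apart. Compound 2 stands at > 10000 nM, which is a limit of the assay and not a number, and because it differs from compound 1 in more than one place, no single change can be held to account for it: the limit of > 10000 nM in this assay, at which 1 of the 3 values shown sits.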